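A few compounds are considered here, and "the series" means these few. Any claim that something is new, unique, unknown or untested is made for them only; others in the source may bear on it.

Compound 1 `Cc1cccc(NC(=O)N[C@H]2CC[C@H](Oc3ccc(F)cc3)CC2)c1` is the starting point. In a functional assay on CRL2813 cells (Homo sapiens) for cytotoxicity, read by sulforhodamine B assay, with a stated time of 5 days (on this read-out lower numbers stand for stronger inhibition and higher numbers for weaker inhibition), compound 1 gives 14400 nM. Its nearest neighbour is compound 2 `COC(=O)c1cccc(NC(=O)N[C@H]2CC[C@H](Oc3ccc(F)cc3)CC2)c1`, which in this assay gives 9200 nM; the step of a 1.6-fold lower number from compound 1 to compound 2 (0.19 log units; within the scatter), so the two compounds cannot be told apart on these data. Compound 3 `O=C(Nc1ccccc1OC(F)(F)F)N[C@H]1CC[C@H](Oc2ccc(F)cc2)CC1` gives in this assay only a limit of the assay, > 20000 nM, so it is one of the values that sit at the limit of > 20000 nM in this assay, at which 1 of the 3 values shown sits, and yields no number to compare.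

Compound 4 `COc1ccc(NC(=O)N[C@H]2CC[C@H](Oc3ccc(F)cc3)CC2)cc1` is not yet measured. It differs from compound 1 by 4-methoxyphenyl in place of 3-methylphenyl on an amide-type nitrogen. Among the measured compounds shown here, no measured step changes the group on this nitrogen in the same way: the only step with a number, from compound 1 to compound 2, swapped a group on the aromatic carbon and stayed within the scatter, while compound 3 carries a different group and gives only a limit. With nothing pointing to a larger change, the expectation for compound 4 in this assay is a step of about a 1.0-fold higher number from compound 1 to compound 4 (0.02 log units; within the scatter), none beyond the scatter. Compound 4 is therefore estimated at 15000 nM, within a range from 6000 nM to 40000 nM.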

Compound 4, half-maximal inhibitory concentration: > 20000 nM
Compound 4 gave a limit, no number; the forecaster's own chance of this, stated with the estimate: 25%; middle value at least 1.3-fold (0.12 log units) away from the limit.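

In this assay compound 4 gives only a limit, > 20000 nM, and not a number. On this amide-type nitrogen, the change is an at least 1.3-fold higher number from compound 1 to compound 4 (0.14 log units; that floor lies within the scatter), so the printed floor does not separate the two compounds, although the real gap could be larger. Replacing 3-methylphenyl with 4-methoxyphenyl gives no sign of stronger inhibition, and compound 4 now joins compound 3 at the top of the measurable range: the limit of > 20000 nM in this assay, at which 2 of the 4 values shown sit.

Going by these compounds, how far compound 4 really lies beyond this limit stays unknown, and this one swap changes both the substituent and its place in the name, so the two effects cannot be separated. On these data alone, whether an amine or a carboxylic acid on this phenyl ring would bring a measurable value also remains open.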